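A few compounds are considered here, and "the series" means these few. Any claim that something is new, unique, unknown or untested is made for them only; others in the source may bear on it.

Working notes on the series. In a functional assay on MCF7 cells (Homo sapiens) for cytotoxicity, read by MTT assay, with a stated time of 48 h (on this read-out higher numbers stand for weaker inhibition and lower numbers for stronger inhibition), compound 1 `COc1cc(-c2nnc3n2NC(c2cccs2)C(C(=O)c2ccc(F)cc2)S3)cc(OC)c1OC` gives 43700 nM and compound 2 `COc1cc(-c2nnc3n2NC(c2cccs2)C(C(=O)c2ccc(Cl)cc2)S3)cc(OC)c1OC` gives 42800 nM. For the measured compounds named here, compound 2 stands lowest of the two numbers so far, but its nearest neighbour is compound 1, and the only measured step, a 1.0-fold lower number from compound 1 to compound 2 (0.01 log units; within the scatter), lies within the scatter, so the two are not separated.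

Compound 3 `COc1cc(C(=O)C2Sc3nnc(-c4cc(OC)c(OC)c(OC)c4)n3NC2c2cccs2)cc(OC)c1OC` is not yet measured. It differs from compound 2 by 3,4,5-trimethoxyphenyl in place of 4-chlorophenyl on a carbonyl carbon. Going by the values given here, the one step on record, from compound 1 to compound 2, also swaps the aryl group on this carbonyl carbon and left the number essentially unchanged. Among the compounds with values here, that step is the only guide here, and the present change is larger than a halogen swap, so no confident direction is claimed. Compound 3 is therefore expected to stay near compound 2, with the estimated step of a 1.2-fold lower number from compound 2 to compound 3 (0.09 log units; within the scatter) set close to no change beyond the scatter. For compound 3 the estimate in this assay is 35000 nM, with a range from 10000 nM to 100000 nM.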

Compound 3, half-maximal inhibitory concentration: 71000 nM
Estimate against measurement, compound 3: 2.0-fold (0.31 log units) below, and the stated range covers the measured number.
By their numbers in this assay, from the lowest: compounds 2, 1 and 3 (each within the scatter of the next).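

Until now this position had shown only a halogen swap; 3,4,5-trimethoxyphenyl on the carbonyl carbon is a different kind of substituent, with hydrogen-bond acceptors that the halogenated aryl groups lack. In this assay the replacement gives a 1.7-fold higher number from compound 2 to compound 3 (0.22 log units; within the scatter) and likewise a 1.6-fold higher number from compound 1 to compound 3 (0.21 log units; within the scatter) so this broader change on the aryl group still does not separate the three compounds. No measured evidence is available to bear on this result.

The compounds shown leave open whether a group of another type on this carbonyl carbon, such as a methyl group or a phenyl ring carrying an amine or a carboxylic acid, would move the number beyond the scatter. Going by these compounds, all three share the rest of the core, so the effect of changes elsewhere remains unknown.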